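A few compounds are considered here, and "the series" means these few. Any claim that something is new, unique, unknown or untested is made for them only; others in the source may bear on it.

Measured so far:
Compound 1 `OB1OCc2ccc(-n3cc(Sc4ccc(O)cc4)c4ccccc43)cc21` gives, as a limit of an ADME assay on L929 cells (Mus musculus) for cytotoxicity, read by resazurin assay, with a stated time of 72 h (a lower number here means a stronger inhibitor, a higher number a weaker inhibitor), rather than a number, > 10 ug/mL.
Compound 2 `CCCNC(=O)c1cccn1-c1ccc2c(c1)B(O)OC2` gives the limit > 10 ug/mL in this assay.
Compound 3 `O=C(c1ccn(-c2ccc3c(c2)B(O)OC3)c1)c1ccccc1Cl` gives the limit > 10 ug/mL in this assay.

Among the compounds with values here, compound 3 therefore stands where every value in this assay stands so far, on (the limit of > 10 ug/mL in this assay, at which 3 of the 3 values shown sit), and no measured step exists in this set. Compound 4 `Cc1cccc(C(=O)c2ccn(-c3ccc4c(c3)B(O)OC4)c2)c1` differs from compound 3 by 3-methylphenyl in place of 2-chlorophenyl on a carbonyl carbon. Within the data shown here, with no measured step to lean on, the expected step from compound 3 to compound 4 is a step that the limit leaves unreadable from compound 3 to compound 4, none beyond the scatter. Compound 4 is estimated at 20 ug/mL in this assay, within a range of 8 ug/mL to 60 ug/mL, most likely again reported only as a limit.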

Compound 4, half-maximal inhibitory concentration: > 10 ug/mL
Compound 4 was reported as a limit; the forecaster's own chance of this, stated with the estimate: 85%; the middle value does not contradict the limit.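

Compound 3 and compound 4 both stand only as limits in this assay, so no step can be read between them: the limit of > 10 ug/mL in this assay, at which 4 of the 4 values shown sit. The compounds shown leave open whether 3-methylphenyl in place of 2-chlorophenyl on a carbonyl carbon shifts the half-maximal inhibitory concentration at all.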